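This account rests on a few compounds, and the source may have more. Where it says the series, first, only, none or still open, it means among the compounds named here.

In a functional assay on SF-268 cells (Homo sapiens) for cytotoxicity, read by sulforhodamine B assay, with a stated time of 48 h, tested at 0.1 uM (on this read-out lower numbers stand for a stronger effect and higher numbers for a weaker effect at the one concentration tested), compound 1 `COc1ccc(-c2cc(/C=C/C(=O)c3ccc(N)cc3)[nH]n2)cc1` gives 93%. Compound 3 `COc1ccc(-c2cc(/C=C/C(=O)c3ccc(N)cc3)[nH]n2)cc1OC` carries methoxy in place of hydrogen on an aromatic carbon, and in this assay compound 3 gives 101%, so that the step of a number 8 percentage points higher from compound 1 to compound 3 (within the scatter). Compound 2 `COc1ccc(C(=O)/C=C/c2cc(-c3cc(OC)c(OC)c(OC)c3)n[nH]2)cc1OC` is built on a different core; how that core differs from the core of compound 1 is not broken down here. In this assay compound 2 gives 89%, a number within the scatter of compound 1, while the number for compound 3 lies higher by more than the scatter. Compound 4 `COc1cc(C(=O)/C=C/c2cc(-c3cc(OC)c(OC)c(OC)c3)n[nH]2)cc(OC)c1OC` carries methoxy in place of hydrogen on an aromatic carbon. Going by the values given here, this is the same kind of change as the one from compound 1 to compound 3, although here the entering group also sits meta to a methoxy group. Because a number 8 percentage points higher from compound 1 to compound 3 (within the scatter), only a small step is expected again, estimated as a number 5 percentage points higher from compound 2 to compound 4 (within the scatter). Compound 4 is therefore expected to give about 94% in this assay, most likely between 82% and 106%.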

Compound 4, a percentage reported as activity, at one concentration (the size of the read-out at that concentration, not a potency): 99%
The estimate for compound 4 lay 5 percentage points below the measured number; low and high end bracket the measured number.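

In this assay, methoxy in place of hydrogen on an aromatic carbon gives a number 10 percentage points higher from compound 2 to compound 4 (within the scatter), and the two cores can be set side by side: the same change on two cores in this assay, a number 8 percentage points higher (within the scatter) from compound 1 to compound 3 and a number 10 percentage points higher (within the scatter) from compound 2 to compound 4, 2 percentage points apart, within the scatter of two such steps. On these two cores, then, the change carries over as a step that stays within the scatter each time. This does not show that methoxy has any real effect on the read-out here, and two cores cannot tell how the change would behave on a third.

The compounds shown leave open whether a different group on that aromatic carbon, such as a hydroxyl group or a carboxylic acid, would give a step beyond the scatter. They also leave open how the same change would read at another concentration.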